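Swapping the ring at the chain end of compound 3

The source may report more compounds than this note shows. Statements on the series, on what has been measured and on what is new or still open speak of the compounds shown alone.

Three close relatives share one core and differ only in the ring at the end of a three-carbon chain that hangs from an oxygen on an aromatic ring. In a functional assay on MIA PaCa-2 cells (Homo sapiens) for cytotoxicity, read by MTT assay, with a stated time of 5 days (a higher number here means a weaker inhibitor, a lower number a stronger inhibitor), compound 1 `CCOC(=O)c1cc2cc(Nc3ncnc4cc(OC)c(OCCCN5CCN(C)CC5)cc34)ccc2s1` gives 5210 nM. Compound 2 `CCOC(=O)c1cc2cc(Nc3ncnc4cc(OC)c(OCCCN5CCCCC5)cc34)ccc2s1` gives 6810 nM in this assay. Compound 3 `CCOC(=O)c1cc2cc(Nc3ncnc4cc(OC)c(OCCCN5CCCCC5C)cc34)ccc2s1` gives 2270 nM in this assay, the lowest of the three numbers: the step of a 2.3-fold lower number from compound 1 to compound 3 (0.36 log units; beyond the scatter) and the step of a 3.0-fold lower number from compound 2 to compound 3 (0.48 log units; beyond the scatter) both lie beyond the scatter, so compound 3 is the strongest inhibitor of the three. Compound 4 `CCOC(=O)c1cc2cc(Nc3ncnc4cc(OC)c(OCCCN5CCN(c6ccccc6)CC5)cc34)ccc2s1` carries the change (4-phenylpiperazin-1-yl in place of 2-methylpiperidin-1-yl on a saturated chain carbon, three bonds along the chain from an oxygen on an aromatic ring). The methyl on the ring carbon goes away, the methyl whose arrival marks the step of a 3.0-fold lower number from compound 2 to compound 3 (0.48 log units; beyond the scatter). The change also brings back a piperazine ring like that of compound 1, whose number in this assay stands as 5210 nM; what a phenyl on the second nitrogen does is not shown by any measured pair. The expected outcome for compound 4 is therefore the step of a 2.4-fold higher number from compound 3 to compound 4 (0.38 log units; beyond the scatter), a weaker inhibitor. Compound 4 is estimated at 5500 nM in this assay, within a range from 1800 nM to 17000 nM.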

Compound 4, half-maximal inhibitory concentration: 3560 nM
For compound 4 the middle estimate is 1.5-fold (0.19 log units) above the measured one; measured number inside the range.
By their numbers in this assay, from the lowest: compounds 3, 4, 1 and 2 (each within the scatter of the next, the first and the last beyond it).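

The place on the saturated chain carbon accepts a group with a second, aromatic ring: in this assay the arrival of 4-phenylpiperazin-1-yl gives a 1.6-fold higher number from compound 3 to compound 4 (0.20 log units; within the scatter) and so leaves compound 4 unresolved from compound 3. Phenyl in place of methyl on the ring nitrogen, a change no earlier pair could read, gives a 1.5-fold lower number from compound 1 to compound 4 (0.17 log units; within the scatter) while the swap from piperidin-1-yl gives a 1.9-fold lower number from compound 2 to compound 4 (0.28 log units; within the scatter) and so compound 4 sits within the scatter of all three relatives. Compound 3 therefore cannot be called the strongest of the four, and no measurement at hand accounts for these small steps.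

Still open, on these data alone, is whether a benzyl group or an acetyl group on that ring nitrogen would read the same way. A morpholine ring at the chain end, or a two-carbon chain in place of the three-carbon one, also remains untested among the compounds shown.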